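Shortening the chain on the aromatic nitrogen

The compounds below may be only part of what the source reports. "The series", "measured", "known", "first", "only" and "open" are said of these compounds alone.

Measured so far:
compound 1 `CCCn1ncnc1-c1ccccc1NCC1=NCCN1`, 316 nM
compound 2 `CC(C)n1nccc1-c1ccccc1NCC1=NCCN1`, < 100000 nM
compound 3 `Cc1nc(-c2ccccc2NCC2=NCCN2)n(C)n1`, < 5020 nM

Within the data shown here, in an in vitro functional assay on cells (Fibroblast) for agonist activity at Alpha-1B adrenergic receptor (Homo sapiens) (a higher number here means that more compound is needed for the effect, a lower number that less compound is needed), compound 1 gives 316 nM, the only real number among the three results. For compound 2 this assay reports a limit, < 100000 nM. For compound 3 this assay likewise reports a limit, < 5020 nM. Among the measured compounds shown here, the two limits, the limit of < 100000 nM in this assay, at which 1 of the 3 values shown sits, and (the limit of < 5020 nM in this assay, at which 1 of the 3 values shown sits), fix no number, so compound 1 alone anchors the series and no measured step can be sized from them.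

Compound 4 `CCn1ncnc1-c1ccccc1NCC1=NCCN1` is the next compound to be measured. It differs from compound 1 in one place: hydrogen in place of methyl on a saturated chain carbon, two bonds along the chain from an aromatic nitrogen. For the measured compounds named here, no measured pair in the set shows a step of this kind, so the expectation rests on the change itself. In this assay a small step is expected, most likely a modest rise in the concentration needed, possibly within the scatter. Compound 4 is therefore expected at 500 nM, with a range from 150 nM to 2000 nM. The expected step of a 1.6-fold higher number from compound 1 to compound 4 (0.20 log units; within the scatter) is small and close to the scatter of repeated measurements.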

Compound 4, half-maximal effective concentration: 63.1 nM
Compound 4: the middle estimate sits 7.9-fold (0.90 log units) above what was measured, outside the stated range (below it).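

In this assay, among these compounds, cutting propyl to ethyl on the aromatic nitrogen gives a 5.0-fold lower number from compound 1 to compound 4 (0.70 log units; beyond the scatter), the first step that can be sized. The position therefore responds to the loss of a single carbon, with the shorter chain needing less compound for the effect, although this direction rests on one pair alone. Nothing shown bears on the cause of this step.

Against compound 4, compound 3 differs in more than one place and reports only a limit, < 5020 nM, so that step cannot be read. On these data alone, it remains open whether the trend carries on to a lone methyl on the aromatic nitrogen of the otherwise unchanged core, and how a cyclopropyl group or a hydroxyethyl chain would fare there.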